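Furan for Naphthalene: Cytotoxicity Likely Stays Beyond Reach

The source may report more compounds than this note shows. Statements on the series, on what has been measured and on what is new or still open speak of the compounds shown alone.

Compound 1 `CC(C)N(Cc1cccc(OCCCCCC(=O)O)c1)C(=O)c1ccc(-c2cccc(N(C)C)c2)cc1`: in an ADME assay on HEK293 cells (Homo sapiens) for cytotoxicity, read by CellTiter-Glo and resazurin assay, with a stated time of 72 h (a higher number here means that more compound is needed for the effect, a lower number that less compound is needed), compound 1 gives > 26000 nM, a limit.
Compound 2 `COc1cc(F)cc(-c2ccc(C(=O)N(Cc3cccc(OCCCCCC(=O)O)c3)C(C)C)cc2)c1`: in this assay compound 2 gives > 26000 nM, a limit.
Compound 3 `CCOC(=O)CCCCCOc1cccc(CN(C(=O)c2ccc(-c3ccc4ccccc4c3)cc2)C(C)C)c1`: in this assay compound 3 gives > 26000 nM, a limit.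

Compound 3 therefore stands where every measured compound stands, at the limit of > 26000 nM in this assay, at which 3 of the 3 values shown sit. For the measured compounds named here, the one step measured, a step that the two limits leave unreadable from compound 1 to compound 2, carries no readable size, since both of its ends are limits. Compound 4 `CCOC(=O)CCCCCOc1cccc(CN(C(=O)c2ccc(-c3ccco3)cc2)C(C)C)c1` differs from compound 3 by furan-2-yl in place of naphthalen-2-yl on an aromatic carbon. Going by the values given here, no measured step touches this part of the molecule, so there is nothing that points to a change in either direction. Compound 4 is expected to show a step that the limit leaves unreadable from compound 3 to compound 4, which means a result once more sitting at the limit rather than a number. In this assay compound 4 is estimated at 30000 nM, within 15000 nM to 60000 nM.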

Compound 4, half-maximal effective concentration: > 26000 nM
Compound 4 ended at the assay's limit; the forecaster's own chance of this, stated with the estimate: 85%; the middle value does not contradict the limit.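

Compound 3 and compound 4 both sit at a limit, so no step can be read between them. The compounds shown leave open whether any change to the shared core would give a readable value in this assay.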